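Catechol vinyl sulfones: saturating and extending the alkyl chain

The source may hold more compounds than are shown below. What is called first, only, known or untested is meant among the compounds shown, and "the series" means these compounds.

Three catechol vinyl sulfones have been run in a functional assay, read by fluorescence and spectrophotometry, with a stated time of 1 h; on this read-out lower numbers stand for an effect already at smaller amounts and higher numbers for an effect only at larger amounts of compound. Compound 1 `C=CCCCCCCCS(=O)(=O)/C=C/c1ccc(O)c(O)c1` gives 6900 nM, the lowest of the three numbers, although its gaps to the others stay within the scatter. Compound 2 `O=S(=O)(/C=C/c1ccc(O)c(O)c1)CC1CCCN1` gives 13800 nM, and compound 3 `CC(C)(C)OC(=O)N1CCCC1CS(=O)(=O)/C=C/c1ccc(O)c(O)c1` gives 7100 nM. Among the compounds with values here, the one single-point step measured, a 1.9-fold lower number from compound 2 to compound 3 (0.29 log units; within the scatter), concerns the ring amine and says nothing about the alkyl chain of compound 1.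

Compound 4 `CCCCCCCCCCS(=O)(=O)/C=C/c1ccc(O)c(O)c1` is compound 1 with the chain end changed: propyl in place of vinyl on a saturated chain carbon, seven bonds along the chain from a sulfonyl sulfur. Within the data shown here, no measured pair touches this part of the molecule, so the expectation rests only on the narrow spread of the three numbers so far and on the smallness of the change. The step is expected to be a 1.1-fold lower number from compound 1 to compound 4 (0.03 log units; within the scatter), that is, nothing beyond the scatter in either direction. In this assay compound 4 is therefore estimated at 6500 nM, with a range from 2500 nM to 17000 nM.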

Compound 4, half-maximal effective concentration: 6800 nM
Compound 4: middle estimate off by 1.0-fold (0.02 log units), on the low side; measured number inside the range.
By their numbers in this assay, from the lowest: compounds 4, 1, 3 and 2 (each within the scatter of the next, the first and the last beyond it).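

In this assay, a 1.0-fold lower number from compound 1 to compound 4 (0.01 log units; within the scatter), so vinyl and propyl cannot be told apart on a saturated chain carbon, seven bonds along the chain from a sulfonyl sulfur. Within the data shown here, this is the only measured step on the alkyl chain, and it shows that the double bond outside aromatic rings is not needed at this place to keep a number of this size. No evidence is available that would explain this flat result.

As far as these compounds go, it remains open whether any change at this chain end can move the number beyond the scatter, for example a longer chain, an amine or a carboxylic acid. A single pair also cannot show whether chain length itself matters, since a much shorter chain such as hexyl is not among the compounds shown.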